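The source may report more compounds than this note shows. Statements on the series, on what has been measured and on what is new or still open speak of the compounds shown alone.

Compounds measured in an ADME assay on MT2 cells (Homo sapiens) for cytotoxicity, read by XTT assay, with a stated time of 4 days; a higher number here means that more compound is tolerated, a lower number that less compound is tolerated:
- compound 1, `Cc1cc(/C=C2\SC(=S)N(c3cccc(C(F)(F)F)c3)C2=O)c(C)n1-c1cccc(-c2nnn[nH]2)c1`: 15800 nM
- compound 2, `Cc1cc(/C=C2\SC(=S)N(c3ccc(O)cc3)C2=O)c(C)n1-c1cccc(-c2nnn[nH]2)c1`: 45600 nM
- compound 3, `Cc1cc(/C=C2\SC(=S)N(c3ccc(Br)cc3)C2=O)c(C)n1-c1cccc(-c2nnn[nH]2)c1`: 46800 nM

Compound 3 has the highest of the three numbers in this assay, although its lead over compound 2 is only a 1.0-fold higher number from compound 2 to compound 3 (0.01 log units; within the scatter), which is within the scatter, so the two cannot be ranked against each other. Compound 1 sits clearly lower: the steps of a 2.9-fold higher number from compound 1 to compound 2 (0.46 log units; beyond the scatter) and a 3.0-fold higher number from compound 1 to compound 3 (0.47 log units; beyond the scatter) are both beyond the scatter and of similar, modest size.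

Compound 4, `Cc1cc(/C=C2\SC(=S)N(Cc3ccccc3)C2=O)c(C)n1-c1cccc(-c2nnn[nH]2)c1`, is not yet measured. It differs from compound 3 in one place: benzyl in place of 4-bromophenyl on an amide-type nitrogen in a ring. For the measured compounds named here, no measured step exchanges an aryl group for a benzyl group on this nitrogen, so the bearing of the earlier steps is indirect. They show that replacing one aromatic group by another on the amide-type nitrogen in the ring moved the number by a modest amount at most, and in one case not beyond the scatter at all. A change of comparable or smaller magnitude is therefore expected here, with no clear direction, and a step of a 1.2-fold lower number from compound 3 to compound 4 (0.07 log units; within the scatter) is anticipated. Compound 4 is accordingly estimated at 40000 nM in this assay, with a plausible range from 15000 nM to 100000 nM.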

Compound 4, half-maximal cytotoxic concentration: 150000 nM
For compound 4 the middle estimate is 3.8-fold (0.57 log units) below the measured one; the whole stated range lies below it.
By their numbers in this assay, from the lowest: compound 1; then compounds 2 and 3 (each within the scatter of the next); then compound 4.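

In this assay, the benzyl group of compound 4 gives a 3.2-fold higher number from compound 3 to compound 4 (0.51 log units; beyond the scatter) and also a 3.3-fold higher number from compound 2 to compound 4 (0.52 log units; beyond the scatter) and finally a 9.5-fold higher number from compound 1 to compound 4 (0.98 log units; beyond the scatter) and so places compound 4 beyond the scatter of all three compounds that carry a substituted phenyl group at this position. The earlier compounds shown here showed only exchanges among substituted phenyl groups, and compound 2 and compound 3 could not be told apart, whereas this change shows that the number at this amide-type nitrogen can still rise above the level they share, even though benzyl and 4-bromophenyl have the same count of heavy atoms and each holds one six-membered aromatic ring of carbon only. Nothing given here accounts for this rise.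

The compounds shown leave open whether a substituted benzyl such as 4-bromobenzyl, a longer chain such as phenethyl, or a plain alkyl chain on this nitrogen would stand with compound 4 or with compound 2 and compound 3. They also leave open how an amine or a carboxylic acid on the benzyl ring would fare at this position.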